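The source may hold more compounds than are shown below. What is called first, only, known or untested is meant among the compounds shown, and "the series" means these compounds.

Measured compounds:
compound 1 `COc1cc(-c2cc(/C=C/C(=O)c3ccc(N)cc3)[nH]n2)cc(OC)c1OC` gives 94%
compound 2 `COc1ccc(C(=O)/C=C/c2cc(-c3cc(OC)c(OC)c(OC)c3)n[nH]2)cc1OC` gives 95%

Both numbers come from a functional assay on U-251 cells (Homo sapiens) for cytotoxicity, read by sulforhodamine B assay, with a stated time of 48 h, tested at 0.1 uM; a higher number here means a weaker effect of the compound at the concentration tested, a lower number a stronger effect. Compound 2 has the highest of the two numbers; the nearest is compound 1, and the step of a number 1 percentage points higher from compound 1 to compound 2 (within the scatter) lies within the scatter. The unmeasured compound 3 `COc1cc(-c2cc(/C=C/C(=O)c3ccc(F)c(F)c3)[nH]n2)cc(OC)c1OC` differs from compound 2 at the same carbonyl carbon: 3,4-difluorophenyl in place of 3,4-dimethoxyphenyl on a carbonyl carbon. Within the data shown here, the only measured step that bears on this, an exchange of the ring on that carbonyl carbon, is a number 1 percentage points higher from compound 1 to compound 2 (within the scatter), which did not move the number. No step beyond the scatter is expected; the expected step is a number 1 percentage points lower from compound 2 to compound 3 (within the scatter). Compound 3 is estimated to give about 94% in this assay, between 82% and 102%.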

Compound 3, a percentage reported as activity, at one concentration (the size of the read-out at that concentration, not a potency): 96%
For compound 3 the middle estimate is 2 percentage points below the measured one, within the range that was stated.
By their numbers in this assay, from the lowest: compounds 1, 2 and 3 (each within the scatter of the next).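

In this assay, a third ring on the carbonyl carbon, 3,4-difluorophenyl, again brings no change beyond the scatter: the number is a number 1 percentage points higher from compound 2 to compound 3 (within the scatter) and a number 2 percentage points higher from compound 1 to compound 3 (within the scatter). This position has now held rings bearing an amine, methoxy groups and fluorine atoms, and these three compounds cannot be told apart at this single concentration. Nothing available explains this result. From the compounds shown here alone, all three compounds carry a phenyl ring on that carbon, so the effect of a carboxylic acid or a simple methyl group there remains open. Going by these compounds, whether the three compounds would separate at higher concentrations also remains open.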